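The source may report more compounds than this note shows. Statements on the series, on what has been measured and on what is new or still open speak of the compounds shown alone.

Of the compounds shown here, two on the shared core have been measured in an ADME assay for permeability, using PAMPA, with a stated time of 4 h, at pH 7.4; on this read-out higher numbers stand for higher permeability and lower numbers for lower permeability. Compound 1 `CCN(CC)CCCCN(C[C@H]1Cc2ncccc2CN1)[C@H]1CCCc2cccnc21` gives 240 nm/s, and compound 2 `CN(CCCCN(C[C@H]1Cc2ncccc2CN1)[C@H]1CCCc2cccnc21)C1CCOCC1` gives 490 nm/s, the higher of the two numbers. Compound 3 `c1cnc2c(c1)CN[C@@H](CN(CCCCN(C1COC1)C1COC1)[C@H]1CCCc3cccnc31)C2` keeps that core and has not yet been measured in this assay. Its structural change from compound 2 is a group of 9 heavy atoms (6 carbon, 1 nitrogen, 2 oxygen; 2 four-membered non-aromatic rings with 1 hetero atom each) in place of a group of 8 heavy atoms (6 carbon, 1 nitrogen, 1 oxygen; one six-membered non-aromatic ring with 1 hetero atom), on a saturated chain carbon, four bonds along the chain from an amine nitrogen. Going by the values given here, this is the same place that differs between the two measured compounds, so only one measured step bears on the new change. That step is modest, and it involves a different pair of groups. Among the compounds with values here, no measured compound carries a four-membered ring, so the guidance is weak and the range must stay wide. Within the data shown here, compound 2 sits at the top of a very short series, and the one step into its group was a 2.0-fold higher number from compound 1 to compound 2 (0.31 log units; beyond the scatter). On that basis only a small upward move is expected, and it would probably stay within the scatter. The expected step is a 1.2-fold higher number from compound 2 to compound 3 (0.09 log units; within the scatter). For compound 3 the estimated value is 600 nm/s, with an expected range from 220 nm/s to 1400 nm/s.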

Compound 3, apparent permeability: 320 nm/s
Compound 3: the middle estimate sits 1.9-fold (0.27 log units) above what was measured; measured number inside the range.
By their numbers in this assay, from the lowest: compounds 1, 3 and 2 (each within the scatter of the next, the first and the last beyond it).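

In this assay, the place on a saturated chain carbon, four bonds along the chain from an amine nitrogen, now holds a third kind of group, with 2 four-membered non-aromatic rings with 1 hetero atom each, and replacing methyl(oxan-4-yl)amino with it gives a 1.5-fold lower number from compound 2 to compound 3 (0.19 log units; within the scatter) and so does not separate the two compounds. Set against diethylamino, the same group gives a 1.3-fold higher number from compound 1 to compound 3 (0.12 log units; within the scatter), so compound 3 cannot be told apart from either neighbour, although the earlier pair alone showed a 2.0-fold higher number from compound 1 to compound 2 (0.31 log units; beyond the scatter) and hinted that a ring-bearing group with an oxygen might carry the number upward, a reading that the second oxygen of the new group does not extend. No measurement at hand accounts for these numbers.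

Going by these compounds alone, still open is whether a group with only one four-membered ring, keeping a methyl on the amine nitrogen, would read like compound 3 or like compound 2. On these data alone, how a morpholine or a plain dimethylamino group would read at this place also remains unknown, as does whether these small steps would hold on any core other than the shared one.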